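A fluorine shift from compound 3 to compound 4

The compounds below may be only part of what the source reports. "The series", "measured", "known", "first", "only" and "open" are said of these compounds alone.

Compound 1 `COc1ccc2[nH]c(-c3cccc(F)c3)cc(=O)c2c1OC`: 3500 nM
Compound 2 `O=c1cc(-c2ccc(F)cc2)[nH]c2ccc(O)c(O)c12`: 100000 nM
Compound 3 `COc1cc2c(=O)cc(-c3ccccc3F)[nH]c2cc1O`: 4400 nM

In a functional assay on NCI-H460 cells (Homo sapiens) for cytotoxicity, read by MTT assay, with a stated time of 48 h (on this read-out higher numbers stand for weaker inhibition and lower numbers for stronger inhibition), compound 3 gives 4400 nM, within the scatter of compound 1 at 3500 nM, while compound 2 stands far higher at 100000 nM. Compound 4 `COc1cc2c(=O)cc(-c3cccc(F)c3)[nH]c2cc1O` has 3-fluorophenyl in place of 2-fluorophenyl on an aromatic carbon, next to the ring nitrogen (3-fluorophenyl in place of 2-fluorophenyl on an aromatic carbon). Among the measured compounds shown here, no measured pair shows this change directly. Compound 1 also carries 3-fluorophenyl and gives 3500 nM, so no step beyond the scatter is expected in this assay, and any shift may be slightly downward. The estimated 1.3-fold lower number from compound 3 to compound 4 (0.10 log units; within the scatter) stays within the scatter. Compound 4 is expected at 3500 nM, with an estimated range of 1200 nM to 10000 nM.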

Compound 4, half-maximal inhibitory concentration: 4800 nM
Compound 4: middle estimate off by 1.4-fold (0.14 log units), on the low side, within the range that was stated.
By their numbers in this assay, from the lowest: compounds 1, 3 and 4 (each within the scatter of the next); then compound 2.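

In this assay, among the compounds shown here, the change to 3-fluorophenyl in place of 2-fluorophenyl gives a 1.1-fold higher number from compound 3 to compound 4 (0.04 log units; within the scatter), the first direct reading of a change at this position. With the rest of the molecule held constant, these two fluorophenyl groups therefore cannot be told apart in this read-out. No available evidence bears on this result. The compounds shown leave open how this position would respond to a group other than fluorophenyl, such as a plain phenyl, a pyridine ring or a phenyl carrying an amine or a carboxylic acid.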